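Chain saturation against a free ring hydroxyl

The compounds below may be only part of what the source reports. "The series", "measured", "known", "first", "only" and "open" are said of these compounds alone.

Compound 1 `CC/C=C\C/C=C\C/C=C\CCCCCCCC1(O)CC(=O)c2c(O)cc(OCOC)cc2O1` sits at 6790 nM in a functional assay on MDA-MB-231 cells (Homo sapiens) for antiproliferative activity, read by MTT assay; on this read-out higher numbers stand for weaker inhibition and lower numbers for stronger inhibition. Compound 2 `CCCCC/C=C\C/C=C\CCCCCCCC1(O)CC(=O)c2c(O)cc(OCOC)cc2O1` carries the change (butyl in place of but-1-en-1-yl on a saturated chain carbon bound to a double-bonded chain carbon); in this assay compound 2 gives 16100 nM, and the step of a 2.4-fold higher number from compound 1 to compound 2 (0.37 log units; beyond the scatter) is the only measured read on this change. Compound 3 `CC/C=C\C/C=C\C/C=C\CCCCCCCC1(O)CC(=O)c2c(O)cc(O)cc2O1` differs from compound 1 by hydrogen in place of methoxymethyl on an oxygen on an aromatic ring; in this assay compound 3 gives 6790 nM, so the two cores stand level, no change at the digits printed from compound 1 to compound 3 (within the scatter), and the core of compound 3 is taken as equivalent to that of compound 1 in this read-out.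

Compound 4 `CCCCC/C=C\C/C=C\CCCCCCCC1(O)CC(=O)c2c(O)cc(O)cc2O1` is not yet measured. It bears, on the core of compound 3, the change (butyl in place of but-1-en-1-yl on a saturated chain carbon bound to a double-bonded chain carbon). The place of the change is the same as from compound 1 to compound 2, word for word, and the two cores differ only by the hydrogen in place of methoxymethyl already noted, which itself made no difference within the scatter. Going by the values given here, the expectation for compound 4 therefore rests on the single earlier step, a 2.4-fold higher number from compound 1 to compound 2 (0.37 log units; beyond the scatter), transferred to the number of compound 3. The step from compound 3 to compound 4 is expected to be a 2.2-fold higher number from compound 3 to compound 4 (0.34 log units; beyond the scatter), a modest rise beyond the scatter, with the caveat that it rests on one pair only. Compound 4 is therefore estimated at 15000 nM in this assay, with a likely range from 7000 nM to 35000 nM.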

Compound 4, half-maximal inhibitory concentration: 6790 nM
For compound 4 the middle estimate is 2.2-fold (0.34 log units) above the measured one; the whole stated range lies above it.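

In this assay, butyl in place of but-1-en-1-yl gives no change at the digits printed from compound 3 to compound 4 (within the scatter), and this step does not separate from its counterpart on the methoxymethyl core: the same change on two cores in this assay, a 2.4-fold higher number (0.37 log units; beyond the scatter) from compound 1 to compound 2 and no change at the digits printed (within the scatter) from compound 3 to compound 4, 2.4-fold (0.37 log units) apart, within the scatter of two such steps Hydrogen in place of methoxymethyl gives a 2.4-fold lower number from compound 2 to compound 4 (0.37 log units; beyond the scatter), and this step likewise does not separate from its counterpart on the other chain: the same change on two cores in this assay, no change at the digits printed (within the scatter) from compound 1 to compound 3 and a 2.4-fold lower number (0.37 log units; beyond the scatter) from compound 2 to compound 4, 2.4-fold (0.37 log units) apart, within the scatter of two such steps These four compounds therefore give no firm sign that either change depends on the core, but they do not show that either change carries over at a fixed size, since each one lies beyond the scatter on one core and within it on the other, and each comparison rests on a single pair of steps.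

Open, from the compounds shown here alone, is whether a fully saturated chain, a shorter chain or a longer chain would follow the same course on the two cores, which would give more than one pair of steps for judging transfer. Also open, going by these compounds, is whether an amine or a carboxylic acid in place of the methoxymethyl group would stand level with the free hydroxyl, or whether these steps would hold in any other read-out.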